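A Third Chlorine Position on the Fluorobenzyl Ring

This account rests on a few compounds, and the source may have more. Where it says the series, first, only, none or still open, it means among the compounds named here.

Compound 2 `CCOC(=O)C1=CCCCC1S(=O)(=O)Cc1ccccc1F` gives 97 nM in a functional assay on RAW264.7 cells (Mus musculus), read by fluorescence; a lower number here means a stronger inhibitor, a higher number a weaker inhibitor. Going by the values given here, of the three numbers measured so far, compound 2 sits close to compound 1 `CCOC(=O)C1=CCCCC1S(=O)(=O)Cc1ccc(Cl)cc1F`, which gives 104 nM in this assay, and well above compound 3 `CCOC(=O)C1=CCCCC1S(=O)(=O)Cc1cccc(Cl)c1F`, which gives 12 nM. Compound 4 `CCOC(=O)C1=CCCCC1S(=O)(=O)Cc1cc(Cl)ccc1F` differs from compound 2 by chloro in place of hydrogen on an aromatic carbon. Two measured steps change a chloro group on this same ring and bear on the question. The step of a 1.1-fold lower number from compound 1 to compound 2 (0.03 log units; within the scatter) shows that a chloro group at one position makes no difference beyond the scatter, while an 8.1-fold lower number from compound 2 to compound 3 (0.91 log units; beyond the scatter) shows that a chloro group at another position brings a modest gain. The new chloro group sits at a third position, meta to a large group and para to the fluoro group, which neither precedent covers, so the outcome is expected to fall somewhere between the two cases. A step of a 1.9-fold lower number from compound 2 to compound 4 (0.29 log units; within the scatter) is therefore expected. Compound 4 is estimated at 50 nM, with a range from 15 nM to 160 nM.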

Compound 4, half-maximal inhibitory concentration: 23 nM
The estimate for compound 4 lay 2.2-fold (0.34 log units) above the measured number; measured number inside the range.
By their numbers in this assay, from the lowest: compounds 3 and 4 (each within the scatter of the next); then compounds 2 and 1 (each within the scatter of the next).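

In this assay, chloro in place of hydrogen at this position, meta to a large group and para to a fluoro group, brings a real gain, with a 4.2-fold lower number from compound 2 to compound 4 (0.63 log units; beyond the scatter) and a step beyond the scatter. Going by these compounds alone, a gain from a chloro group on this ring is therefore not tied to the single position in compound 3, whereas the chloro group of compound 1 still makes no difference beyond the scatter, with a 1.1-fold lower number from compound 1 to compound 2 (0.03 log units; within the scatter) on its removal. Nothing available explains why one position responds and another does not. The compounds shown leave open whether a methyl or methoxy group at this position would match chloro, and whether chloro groups at both responsive positions would add up. As far as these compounds go, how a carboxylic acid in place of the ethyl ester would behave also remains open.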